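Fluoro to Chloro on Compound 3

The source may hold more compounds than are shown below. What is called first, only, known or untested is meant among the compounds shown, and "the series" means these compounds.

Compound 1 (`COc1cc(NC(C)CCCNC(=O)NNC(=O)Nc2ccc(F)cc2)c2ncccc2c1`), compound 2 (`COc1cc(NC(C)CCCNC(=O)NNC(=O)Nc2ccc(C(F)(F)F)cc2)c2ncccc2c1`) and compound 3 (`COc1cc(NC(C)CCCNC(=O)NNC(=O)Nc2cccc(F)c2)c2ncccc2c1`) share one core. In a functional assay on CCRF-CEM cells (Homo sapiens) for inhibition, read by MTT assay, with a stated time of 72 h (on this read-out lower numbers stand for stronger inhibition and higher numbers for weaker inhibition), compound 3 gives 98000 nM and matches compound 1 at 118000 nM within the scatter, while compound 2 stands lowest at 18000 nM of the three. Compound 4 (`COc1cc(NC(C)CCCNC(=O)NNC(=O)Nc2cccc(Cl)c2)c2ncccc2c1`) differs from compound 3 by one change (chloro in place of fluoro on an aromatic carbon): chloro in place of fluoro on an aromatic carbon. Moving the fluoro made little difference (a 1.2-fold lower number from compound 1 to compound 3 (0.08 log units; within the scatter)), whereas trifluoromethyl in place of fluoro gave a modest step (a 6.6-fold lower number from compound 1 to compound 2 (0.82 log units; beyond the scatter)). A smaller step in that same direction is therefore expected (a 2.0-fold lower number from compound 3 to compound 4 (0.29 log units; within the scatter)) in this assay and should lie near the edge of the scatter. For compound 4 the estimated value is 50000 nM with an expected range from 20000 nM to 110000 nM overall.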

Compound 4, half-maximal inhibitory concentration: 81000 nM
Compound 4: middle estimate off by 1.6-fold (0.21 log units), on the low side; the range from low to high includes it.
By their numbers in this assay, from the lowest: compound 2; then compounds 4, 3 and 1 (each within the scatter of the next).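

Replacing fluoro with chloro on this aromatic carbon leaves the number unresolved in this assay because a 1.2-fold lower number from compound 3 to compound 4 (0.08 log units; within the scatter) stays within the scatter, and a 1.5-fold lower number from compound 1 to compound 4 (0.16 log units; within the scatter) does too. The chloro compound therefore groups with the two fluoro compounds, whereas a clear gap remains to the trifluoromethyl compound, with a 4.5-fold higher number from compound 2 to compound 4 (0.65 log units; beyond the scatter) lying beyond the scatter. No measurement shown here explains these results.

Going by these compounds, compound 2 differs from compound 4 in both group and place, so the origin of that gap stays open. Trifluoromethyl on the same carbon as the chloro of compound 4 could separate the two, while bromo or methoxy there would test other groups.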